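A Fluorinated Sulfonamide Variant of a Benzanilide

The source may hold more compounds than are shown below. What is called first, only, known or untested is meant among the compounds shown, and "the series" means these compounds.

Compound 1 `COc1ccc(C(=O)Nc2ccc(NS(C)(=O)=O)c(OCc3cc(OC)ccc3OC)c2)cc1`: 13.4 nM
Compound 2 `COc1ccc(OC)c(COc2cc(NC(=O)c3ccc4ccccc4c3)ccc2NS(C)(=O)=O)c1`: 13.3 nM

In a functional assay on SK-BR-3 cells (Homo sapiens) for antiproliferative activity, read by MTT assay, with a stated time of 48 h (a lower number here means a stronger inhibitor, a higher number a weaker inhibitor), compound 1 gives 13.4 nM and compound 2 gives 13.3 nM. The step of a 1.0-fold lower number from compound 1 to compound 2 (0.00 log units; within the scatter) lies within the scatter, so the two compounds sit side by side with no difference that can be read. Compound 3 `COc1ccc(OC)c(COc2cc(NC(=O)c3ccc4ccccc4c3)ccc2N(C)S(=O)(=O)C(F)(F)F)c1` differs from compound 2 in one place: methyl((trifluoromethyl)sulfonyl)amino in place of methanesulfonamido on an aromatic carbon. Going by the values given here, no measured step touches this group; the only measured step, a 1.0-fold lower number from compound 1 to compound 2 (0.00 log units; within the scatter), alters the group on the carbonyl carbon instead. With nothing to go on, the expectation is no step beyond the scatter, a 1.5-fold higher number from compound 2 to compound 3 (0.18 log units; within the scatter), with wide uncertainty. Compound 3 is therefore estimated at 20 nM, between 6 nM and 80 nM.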

Compound 3, half-maximal inhibitory concentration: 200 nM
The estimate for compound 3 lay 10-fold (1.00 log units) below the measured number; measured number above the stated range.
By their numbers in this assay, from the lowest: compounds 2 and 1 (each within the scatter of the next); then compound 3.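

In this assay the aromatic carbon para to a large group proves sensitive: methyl((trifluoromethyl)sulfonyl)amino in place of methanesulfonamido gives a 15-fold higher number from compound 2 to compound 3 (1.18 log units; beyond the scatter) and so a much weaker inhibitor. The earlier change on the carbonyl carbon showed no such effect. No measurement shown explains this loss. Going by these compounds, the swap adds a methyl on the nitrogen and a trifluoromethyl on the sulfur together, so the share of each remains unknown. Also open, on these data alone, is how a plain amine or a carboxylic acid would behave at this position.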